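From compound 2 to compound 4: a difluorophenyl swap

A few compounds are considered here, and "the series" means these few. Any claim that something is new, unique, unknown or untested is made for them only; others in the source may bear on it.

Measured in a functional assay on NCI-H520 cells (Homo sapiens) for cytotoxicity; a higher number here means a weaker inhibitor of growth, a lower number a stronger inhibitor of growth:
- compound 1 `COc1ccc(C2=C(c3cc(OC)c(OC)c(OC)c3)CC3CCCN3C2=O)cc1O`: > 100000 nM (a limit of the assay)
- compound 2 `COc1ccc(C2=C(c3ccc(SC)cc3)CC3CCCN3C2=O)cc1O`: 6000 nM
- compound 3 `COc1ccc(C2=C(c3ccc(SC)cc3)CC3CCCN3C2=O)cc1OC(=O)C1CCCN1C(=O)OC(C)(C)C`: 5000 nM

Among the compounds with values here, compound 2 at 6000 nM and compound 3 at 5000 nM lie within the scatter of each other, so compound 2 stands level with the only other compound that has a number. Compound 1 reports only a limit, > 100000 nM.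

The next compound to be tested is compound 4 `CSc1ccc(C2=C(c3ccc(F)c(F)c3)C(=O)N3CCCC3C2)cc1`. Its difference from compound 2 is 3,4-difluorophenyl in place of 3-hydroxy-4-methoxyphenyl on a double-bonded ring carbon, next to the ring atom that bears a 4-(methylsulfanyl)phenyl group, which stays.

Within the data shown here, no measured step bears on this change, so the expectation is loose: a moderate step in this assay towards a higher number, not far beyond the scatter. The lean to a higher rather than a lower number rests on compound 2 at 6000 nM and compound 3 at 5000 nM being the lowest numbers the series has shown so far. The expected step is a 2.0-fold higher number from compound 2 to compound 4 (0.30 log units; within the scatter). The estimate for compound 4 is 12000 nM, with an expected range of 3000 nM to 50000 nM.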

Compound 4, concentration for 50% growth inhibition: 200 nM
The estimate for compound 4 lay 60-fold (1.78 log units) above the measured number; measured number below the stated range.
By their numbers in this assay, from the lowest: compound 4; then compounds 3 and 2 (each within the scatter of the next). At a limit, above all of these: compound 1.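

In this assay, the 3-hydroxy-4-methoxyphenyl group turns out not to be required on this double-bonded ring carbon: 3,4-difluorophenyl in its place, with the 4-(methylsulfanyl)phenyl group unchanged, gives a 30-fold lower number from compound 2 to compound 4 (1.48 log units; beyond the scatter). Within the data shown here, this is the first measured change of the whole ring at this position, and it shows that a ring with no hydrogen-bond donor or acceptor can stand here while growth inhibition improves, which compound 2 and compound 3, both keeping the oxygen substituents, could not show. Nothing at hand accounts for the size of this step.

The swap changes both ring substituents at once, so the compounds shown leave open whether the step follows from losing the hydroxyl, losing the methoxy, or gaining either fluorine, and a ring with a single fluorine would begin to separate these. Also open, from the compounds shown here alone, is how far the position tolerates other groups, such as a chlorine, a nitrile or an amine, and whether the 3,4-difluorophenyl gain holds with another group in place of the 4-(methylsulfanyl)phenyl.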